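The source may hold more compounds than are shown below. What is called first, only, known or untested is meant among the compounds shown, and "the series" means these compounds.

Compound 3 `NCCn1cc(C(=O)c2ccn3c2CSC3c2cccnc2)c2ccc(-c3ccc(F)cc3)cc21` gives 38 nM in a functional assay (Oryctolagus cuniculus) for antagonist activity at platelet-activating factor receptor (Cavia porcellus); on this read-out higher numbers stand for weaker inhibition and lower numbers for stronger inhibition. Among the three numbers in hand it stands second highest: compound 1 `O=C(c1ccn2c1CSC2c1cccnc1)c1c[nH]c2cc(-c3ccc(F)cc3)ccc12` with 75 nM is nearest, and compound 2 `Cn1cc(C(=O)c2ccn3c2CSC3c2cccnc2)c2ccc(-c3ccc(F)cc3)cc21` with 7 nM is furthest, since a 5.4-fold higher number from compound 2 to compound 3 (0.73 log units; beyond the scatter). Compound 4 `O=C(O)CCn1cc(C(=O)c2ccn3c2CSC3c2cccnc2)c2ccc(-c3ccc(F)cc3)cc21` differs from compound 3 in one place: carboxy in place of amino on a saturated chain carbon, two bonds along the chain from an aromatic nitrogen. Within the data shown here, no measured step swaps amino for carboxy; the steps that touch this chain are an 11-fold lower number from compound 1 to compound 2 (1.03 log units; beyond the scatter) and a 2.0-fold lower number from compound 1 to compound 3 (0.30 log units; within the scatter), both on the substituent of the aromatic nitrogen rather than on its end group. The precedent is therefore indirect, and no step beyond the scatter is foreseen. Compound 4 is expected to show a 1.6-fold higher number from compound 3 to compound 4 (0.20 log units; within the scatter), with an estimated 60 nM and a range from 15 nM to 250 nM.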

Compound 4, inhibition constant: 160 nM
Estimate against measurement, compound 4: 2.7-fold (0.43 log units) below, and the stated range covers the measured number.
By their numbers in this assay, from the lowest: compound 2; then compounds 3 and 1 (each within the scatter of the next); then compound 4.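

In this assay what ends the chain on the aromatic nitrogen counts, not only the chain itself: carboxy in place of amino gives a 4.2-fold higher number from compound 3 to compound 4 (0.62 log units; beyond the scatter) at this position. The 2-carboxyethyl group also falls back against the other substituents, with a 23-fold higher number from compound 2 to compound 4 (1.36 log units; beyond the scatter) against methyl and a 2.1-fold higher number from compound 1 to compound 4 (0.33 log units; beyond the scatter) against hydrogen, so it alone among those shown reads weaker than hydrogen on that nitrogen. Nothing at hand explains this change. The compounds shown leave open how an ethyl group or a 2-hydroxyethyl group would read here. They also leave open whether a longer chain ending in a carboxylic acid or an amine would read differently.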